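Butyl to 3-chloropropyl at the chain end

The compounds below may be only part of what the source reports. "The series", "measured", "known", "first", "only" and "open" are said of these compounds alone.

Among the measured compounds shown here, in a functional assay on MiaPaCa cells (Homo sapiens) for antiproliferative activity, read by sulforhodamine B assay, with a stated time of 48 h (a higher number here means a weaker inhibitor of growth, a lower number a stronger inhibitor of growth), compound 2 `CCCCc1cn(CCCN2C(=O)COc3ccccc32)nn1` gives 2500 nM, the lower of the two numbers so far, and compound 1 `O=C1COc2ccccc2N1CCCn1cc(-c2ccccc2)nn1` gives 94000 nM. Compound 3 `O=C1COc2ccccc2N1CCCn1cc(CCCCl)nn1` carries chloro in place of methyl on a saturated chain carbon, three bonds along the chain from an aromatic carbon, which amounts to butyl to 3-chloropropyl. For the measured compounds named here, the only measured step, a 38-fold lower number from compound 1 to compound 2 (1.58 log units; beyond the scatter), replaced phenyl with butyl on an aromatic carbon. Going by the values given here, compound 3 keeps a chain there, so that large step offers no direct guide, and no measured step covers chloro for methyl. No change beyond the scatter is expected in this assay, and the expected step is a 1.4-fold higher number from compound 2 to compound 3 (0.15 log units; within the scatter). For compound 3 the estimate is 3500 nM, with an expected range of 1000 nM to 12000 nM.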

Compound 3, concentration for 50% growth inhibition: 12500 nM
Compound 3: the middle estimate sits 3.6-fold (0.55 log units) below what was measured; measured number above the stated range.
By their numbers in this assay, from the lowest: compound 2; then compound 3; then compound 1.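

In this assay, chloro in place of methyl on a saturated chain carbon, three bonds along the chain from an aromatic carbon, gives a 5.0-fold higher number from compound 2 to compound 3 (0.70 log units; beyond the scatter) and so costs activity, even with no change in heavy-atom count. The 3-chloropropyl chain still beats phenyl, with a 7.5-fold lower number from compound 1 to compound 3 (0.88 log units; beyond the scatter) on that swap. Nothing available explains the effect of chloro here.

Open, on these data alone, is whether a hydroxyl or an amine at the chain end, or a longer chain, would match or pass compound 2.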